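Dimethoxy groups on the chain-end phenyl: what to expect

A few compounds are considered here, and "the series" means these few. Any claim that something is new, unique, unknown or untested is made for them only; others in the source may bear on it.

Compound 1 `O=C(/C=C/c1ccccc1)c1ccc(N2CCN(c3ccc(Cl)c(Cl)c3)CC2)cc1`: 13.4%
Compound 2 `Cc1ccc(N2CCN(c3ccc(C(=O)/C=C/c4ccccc4)cc3)CC2)cc1`: 2.85%

Both numbers come from a functional assay on the whole organism (strain Kunming) for inhibition, with Mus musculus as the target, with a stated time of 1 h, at a dose of 40 mg/kg by the oral route; a lower number here means less inhibition, a higher number more inhibition at the dose given (going by the name of the read-out). Among the measured compounds shown here, compound 1 stands highest of the two measured compounds, and the only known step, a number 10.6 percentage points lower from compound 1 to compound 2 (beyond the scatter), comes with 4-methylphenyl in place of 3,4-dichlorophenyl on an amine nitrogen in a ring. Compound 3 `COc1ccc(/C=C/C(=O)c2ccc(N3CCN(c4ccc(Cl)c(Cl)c4)CC3)cc2)cc1OC` keeps the 3,4-dichlorophenyl of compound 1 and changes a different place on the shared core: 3,4-dimethoxyphenyl in place of phenyl on a double-bonded chain carbon bound to a double-bonded chain carbon. For the measured compounds named here, no measured step touches that place, so the single known step says nothing about the direction or size of this change. With nothing to point either way, the estimate for compound 3 is a step of a number 0.6 percentage points higher from compound 1 to compound 3 (within the scatter), that is none beyond the scatter, and compound 3 is expected to give about 14%, with a range from 2% to 30%.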

Compound 3, a percentage reported as inhibition, in the whole organism at one dose (the size of the read-out at that dose, not a potency): 63.5%
For compound 3 the middle estimate is 49.5 percentage points below the measured one, and the stated range ends below it.
By their numbers in this assay, from the lowest: compound 2; then compound 1; then compound 3.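

In this assay, the phenyl on a double-bonded chain carbon bound to a double-bonded chain carbon proves to be a sensitive place: 3,4-dimethoxyphenyl in its stead goes with a number 50.1 percentage points higher from compound 1 to compound 3 (beyond the scatter). That step is large, while the one seen earlier on the amine nitrogen in a ring, a number 10.6 percentage points lower from compound 1 to compound 2 (beyond the scatter), is modest, though this rests on a single pair of compounds. Nothing available bears on why the read-out rises so far.

The two methoxy groups enter together, so the compounds shown do not tell whether a single methoxy group, or a hydroxyl or a chlorine on that phenyl, would give a similar rise. On these data alone, it also remains open whether the same change would lift a compound carrying the 4-methylphenyl of compound 2.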